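Sec-butoxy in place of isopropoxy on the oxadiazole series

The compounds below may be only part of what the source reports. "The series", "measured", "known", "first", "only" and "open" are said of these compounds alone.

Compound 1 `Cc1cc(CCC(=O)O)ccc1-c1noc(-c2ccc(OC(C)C)c(F)c2)n1`: in a functional assay on CHO cells with sphingosine 1-phosphate receptor 4 (Homo sapiens) as the target, read by GTPgammaS binding (a higher number here means that more compound is needed for the effect, a lower number that less compound is needed), compound 1 gives only a limit, > 10000 nM.
Compound 2 `Cc1cc(CCC(=O)O)ccc1-c1noc(-c2ccc(OC(C)C)c(C#N)c2)n1`: in this assay compound 2 likewise gives only a limit, > 10000 nM.

Both values are limits of the assay, not numbers, so the step that the two limits leave unreadable from compound 1 to compound 2 cannot be read. Within the data shown here, compound 2 therefore stands at the limit of this assay, as does the only other compound measured: the limit of > 10000 nM in this assay, at which 2 of the 2 values shown sit.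

Compound 3 `CC[C@H](C)Oc1ccc(-c2nc(-c3ccc(CCC(=O)O)cc3C)no2)cc1C#N` differs from compound 2 by methyl in place of hydrogen on a saturated chain carbon, two bonds along the chain from an oxygen on an aromatic ring. Among the measured compounds shown here, no measured step bears on this change; the single measured step, from fluoro to cyano, is itself unreadable. The alkoxy group is the only part of the structure that moves here, and nothing measured says how the assay responds to it.

With compound 2 at the limit and no readable step available, compound 3 is expected to remain at or near the limit in this assay, and the step that the limit leaves unreadable from compound 2 to compound 3 is expected to be small or not determinable. Compound 3 is estimated at 15000 nM, with a range from 3000 nM to 80000 nM, most probably reported again as a limit.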

Compound 3, half-maximal effective concentration: > 10000 nM
Compound 3 ended at the assay's limit; the forecaster's own chance of this, stated with the estimate: 80%; the middle value does not contradict the limit.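

In this assay compound 3 gives > 10000 nM as a limit and not a number. No step can be read between compound 2 and compound 3, and all the compounds shown sit at the same place: the limit of > 10000 nM in this assay, at which 3 of the 3 values shown sit.

The compounds shown leave open whether any change to the alkoxy group or the nitrile brings a readable value in this assay for this series.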